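The source may hold more compounds than are shown below. What is called first, only, known or untested is meant among the compounds shown, and "the series" means these compounds.

Compound 1 `CCCCc1ccccc1C(SCCC(=O)O)SCCC(=O)O` and compound 2 `CCCCCCCCCCCOc1ccccc1C(SCCC(=O)O)SCCC(=O)O` share one core and differ in the substituent on the aromatic ring. In an assay on membranes from lung (Cavia porcellus) for binding affinity to cysteinyl leukotriene receptor (Homo sapiens) (a lower number here means a stronger inhibitor, a higher number a weaker inhibitor), compound 1 gives > 20000 nM, which is a limit of the assay and not a number. In this assay compound 2 gives 287 nM. For the measured compounds named here, compound 2 thus stands as the only measured number in the set; the one other entry is the limit of > 20000 nM in this assay, at which 1 of the 2 values shown sits. Going by the values given here, no pair of measured compounds differs in a single place, so no measured step is available and the two values are simply set side by side. Compound 3 `O=C(O)CCSC(SCCC(=O)O)c1ccccc1OCCCC1CCCCC1` is not yet measured. It differs from compound 2 by cyclohexyl in place of octyl on a saturated chain carbon, three bonds along the chain from an oxygen on an aromatic ring. In this assay the step is expected to run toward weaker binding, beyond the scatter, as a 3.5-fold higher number from compound 2 to compound 3 (0.54 log units; beyond the scatter). Compound 3 is estimated at 1000 nM, with a range from 300 nM to 5000 nM.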

Compound 3, inhibition constant: 1010 nM
Beside the measured number, compound 3's estimate is 1.0-fold (0.00 log units) below it; measured number inside the range.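

In this assay, cyclohexyl in place of octyl on a saturated chain carbon, three bonds along the chain from an oxygen on an aromatic ring, gives a 3.5-fold higher number from compound 2 to compound 3 (0.55 log units; beyond the scatter). For the compounds shown here, this is the first single-place comparison, and it shows that a ring at this position still gives a measured number: compound 3 stands at 1010 nM. Nothing measured here gives a cause for this step.

The change replaces an open chain with a ring and also shortens the substituent, so the size of the step cannot be assigned to either difference alone. A straight hexyl at the same place would separate the two, and a phenyl would test an aromatic ring there.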